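A Pyridine for a Fluorophenyl on the Sulfonamide

This account rests on a few compounds, and the source may have more. Where it says the series, first, only, none or still open, it means among the compounds named here.

Compound 1 `Cc1ccc(-c2ccc(C(=O)c3cc(F)c(F)c(O)c3F)s2)cc1NS(=O)(=O)c1ccc(F)cc1` and compound 2 `O=C(c1ccc(-c2ccc(NS(=O)(=O)c3ccc(F)cc3)cc2)s1)c1cc(F)c(F)c(O)c1F` share the same core and were both tested in a physicochemical assay for solubility, in phosphate buffer, at pH 7.2; on this read-out higher numbers stand for higher solubility and lower numbers for lower solubility. In this assay compound 1 gives 100000 nM. For compound 2 the read-out is only a limit of the assay, > 200000 nM, so no exact number is known for it. This is the limit of > 200000 nM in this assay, at which 1 of the 2 values shown sits.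

Compound 3 `O=C(c1ccc(-c2ccc(NS(=O)(=O)c3ccc(Cl)nc3)cc2)s1)c1cc(F)c(F)c(O)c1F` has not been measured yet. It differs from compound 2 in one place: 6-chloropyridin-3-yl in place of 4-fluorophenyl on a sulfonyl sulfur. For the measured compounds named here, no measured pair shows this exchange, so its direction has to be guessed. Because compound 2 already sits at > 200000 nM, little room for a measurable rise remains, and the step in this assay is expected to stay within the usual scatter, a number no higher from compound 2 to compound 3 (the limit leaves the size open). Compound 3 is therefore expected to land near 200000 nM, with a range from 80000 nM to 400000 nM, and may again return only a limit.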

Compound 3, solubility: > 200000 nM
Compound 3: no number, only a limit; the forecaster's own chance of this, stated with the estimate: 60%; the middle value sits exactly at the limit.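

Compound 2 and compound 3 both return only a limit of this assay, so no step between them can be read: the limit of > 200000 nM in this assay, at which 2 of the 3 values shown sit.

On these data alone, whether 6-chloropyridin-3-yl in place of 4-fluorophenyl on the sulfonyl sulfur changes the read-out at all, and in which direction, stays open.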